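A few compounds are considered here, and "the series" means these few. Any claim that something is new, unique, unknown or untested is made for them only; others in the source may bear on it.

Measured in a functional assay on NCI-H460 cells (Homo sapiens) for inhibition, with a stated time of 72 h; a higher number here means a weaker inhibitor, a lower number a stronger inhibitor:
- compound 1 `COc1ccc(S(=O)(=O)N2CCc3cccc(-c4ccc(N)cc4)c32)cc1`: 288 nM
- compound 2 `COc1ccc(S(=O)(=O)N2CCc3cccc(-c4ccc(F)cc4)c32)cc1`: 95.5 nM
- compound 3 `COc1ccc(-c2cccc3c2N(S(=O)(=O)c2ccc(OC)cc2)CC3)cc1`: 302 nM

Compound 3 stands level with compound 1, as a 1.0-fold higher number from compound 1 to compound 3 (0.02 log units; within the scatter) shows, while its number lies clearly above that of compound 2, as a 3.2-fold higher number from compound 2 to compound 3 (0.50 log units; beyond the scatter) shows. Compound 4 `COc1ccc(S(=O)(=O)N2CCc3cccc(-c4ccc(C#N)cc4)c32)cc1` carries cyano in place of methoxy on an aromatic carbon. Among the measured compounds shown here, no measured step shows this exchange directly, but three steps concern the same aromatic carbon. Two of them separate the groups by a modest amount: a 3.0-fold lower number from compound 1 to compound 2 (0.48 log units; beyond the scatter) and a 3.2-fold higher number from compound 2 to compound 3 (0.50 log units; beyond the scatter). The third, a 1.0-fold higher number from compound 1 to compound 3 (0.02 log units; within the scatter), stays within the scatter. Cyano could therefore behave like the fluoro of compound 2 or like the groups of compounds 1 and 3, so a modest step to a lower number is expected, though no change beyond the scatter remains possible. The estimated step is a 2.0-fold lower number from compound 3 to compound 4 (0.30 log units; within the scatter). For compound 4 the estimated value in this assay is 150 nM, with an expected range from 55 nM to 400 nM.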

Compound 4, half-maximal inhibitory concentration: 29.5 nM
Estimate against measurement, compound 4: 5.1-fold (0.71 log units) above; measured number outside the range, below it.
By their numbers in this assay, from the lowest: compound 4; then compound 2; then compounds 1 and 3 (each within the scatter of the next).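

In this assay, among the compounds shown here, this aromatic carbon proves far more sensitive than the earlier compounds suggested: going from 4-methoxyphenyl to 4-cyanophenyl gives a 10-fold lower number from compound 3 to compound 4 (1.01 log units; beyond the scatter) and exceeds every step seen before at this position. Cyano also goes beyond fluoro, the best group until now, with a 3.2-fold lower number from compound 2 to compound 4 (0.51 log units; beyond the scatter) and beyond amino with a 9.8-fold lower number from compound 1 to compound 4 (0.99 log units; beyond the scatter) as the further step, which makes compound 4 the strongest inhibitor of the four. The groups now fall into three levels, with cyano lowest, fluoro next, and amino and methoxy level with each other at the top.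

As far as these compounds go, whether a trifluoromethyl group, a carboxylic acid or an amide on this carbon would match or pass cyano stays open. Nothing at hand explains why the groups fall in this order.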